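The source may hold more compounds than are shown below. What is called first, only, known or untested is meant among the compounds shown, and "the series" means these compounds.

Among the compounds with values here, compound 2 `Cc1ccc(N2C(=O)[C@H]3[C@H](ON4[C@@H]3C(=O)N(C)[C@@]43C[C@H](C)CC[C@H]3C(C)C)C2=O)c(C)c1` has the higher of the two numbers so far: in a functional assay, read by spectrophotometry, with a stated time of 2 h, tested at 2.5 mg/mL (a lower number here means a weaker effect, a higher number a stronger effect of the compound at the concentration tested), compound 2 gives 65.6%, and its nearest neighbour is compound 1 `CC(C)[C@@H]1CC[C@@H](C)C[C@@]12N(C)C(=O)[C@@H]1[C@H]3C(=O)N(C)C(=O)[C@H]3ON12`, for which this assay gives 57.2%. Within the data shown here, the single measured step, a number 8.4 percentage points higher from compound 1 to compound 2 (within the scatter), is within the scatter, so the two measured compounds cannot be ordered.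

Compound 3 `CC(C)[C@@H]1CC[C@@H](C)C[C@@]12N(C)C(=O)[C@@H]1[C@H]3C(=O)N(c4ccc5ccccc5c4)C(=O)[C@H]3ON12` carries the change (naphthalen-2-yl in place of 2,4-dimethylphenyl on an amide-type nitrogen in a ring). Among the measured compounds shown here, the only step that bears on it is the one from compound 1 to compound 2, where a 2,4-dimethylphenyl replaced a methyl on the same amide-type nitrogen in a ring, and that step stayed within the scatter. Here one aryl group replaces another on the same nitrogen, with no change in hydrogen-bond donors or acceptors. No movement beyond the scatter is therefore expected: the step of a number 1.6 percentage points lower from compound 2 to compound 3 (within the scatter) is estimated to be small. Compound 3 is expected to give about 64% in this assay, within 50% to 78%.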

Compound 3, a percentage reported as activity, at one concentration (the size of the read-out at that concentration, not a potency): 45.1%
The estimate for compound 3 lay 18.9 percentage points above the measured number, outside the stated range (below it).
By their numbers in this assay, from the lowest: compound 3; then compounds 1 and 2 (each within the scatter of the next).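

In this assay, the amide-type nitrogen in a ring now shows that a change at this position can move the read-out beyond the scatter: naphthalen-2-yl in place of 2,4-dimethylphenyl gives a number 20.5 percentage points lower from compound 2 to compound 3 (beyond the scatter) on a swap of one carbon-only aryl group for another. Naphthalen-2-yl in place of methyl gives a number 12.1 percentage points lower from compound 1 to compound 3 (beyond the scatter) while 2,4-dimethylphenyl in place of methyl gave a number 8.4 percentage points higher from compound 1 to compound 2 (within the scatter) so, across these three compounds, which aryl group sits on this nitrogen matters, not only whether one is present. Nothing available bears on the reason for this drop.

From the compounds shown here alone, whether a plain phenyl, a pyridyl ring or a benzyl group on this nitrogen would read with compound 3 or with compounds 1 and 2 remains open. Going by these compounds, with one concentration per compound, these read-outs show only a stronger or weaker effect at that concentration, and whether the effect would differ in the same way at other concentrations also remains open.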